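The source may report more compounds than this note shows. Statements on the series, on what has been measured and on what is new or still open speak of the compounds shown alone.

Among the measured compounds shown here, in an ADME assay for permeability, using PAMPA, at pH 5.5 (a lower number here means that the compound crosses the layer more slowly, a higher number that the compound crosses the layer faster), compound 2 `CCCCc1nc(=O)c(S(=O)(=O)c2ccc(-n3ccccc3=O)cc2)c(O)n1-c1c(OC)cccc1OC` gives 12 nm/s, the lowest of the three numbers so far. Compound 1 `CCCCc1nc(=O)c(S(=O)(=O)c2ccc(-c3cccnc3)cc2)c(O)n1-c1c(OC)cccc1OC` gives 202 nm/s, and compound 3 `CCCCc1[nH]c(=O)c(S(=O)(=O)c2ccc(-c3ccncc3C)cc2)c(O)c1-c1c(OC)cccc1OC` gives 355 nm/s; both lie beyond the scatter from compound 2.

Compound 4 `CCCCc1nc(=O)c(S(=O)(=O)c2ccc(C3CC3)cc2)c(O)n1-c1c(OC)cccc1OC` differs from compound 2 by a group of 3 heavy atoms (3 carbon; one three-membered non-aromatic ring of carbon only) in place of a group of 7 heavy atoms (5 carbon, 1 nitrogen, 1 oxygen; one six-membered aromatic ring with 1 hetero atom), on an aromatic carbon, on an aromatic carbon of a six-membered aromatic ring of carbon only, para to a large group.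

For the measured compounds named here, only one measured step bears on this change. The group that compound 4 gives up is the one that came in at a 17-fold lower number from compound 1 to compound 2 (1.23 log units; beyond the scatter), a large step beyond the scatter. Going by the values given here, no measured compound carries cyclopropyl, so that single step is a loose guide, and it involves a different partner group.

A large move to a higher number in this assay is still expected, well beyond the scatter, and the expected step is a 21-fold higher number from compound 2 to compound 4 (1.32 log units; beyond the scatter). For compound 4 the estimate is 250 nm/s, with an expected range from 80 nm/s to 700 nm/s.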

Compound 4, apparent permeability: 615 nm/s
For compound 4 the middle estimate is 2.5-fold (0.39 log units) below the measured one, and the stated range covers the measured number.
By their numbers in this assay, from the lowest: compound 2; then compounds 1, 3 and 4 (each within the scatter of the next, the first and the last beyond it).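

Cyclopropyl on this aromatic carbon, para to a large group, gives a 51-fold higher number from compound 2 to compound 4 (1.71 log units; beyond the scatter) in this assay, the largest step in the series so far. Set against pyridin-3-yl, it gives a 3.0-fold higher number from compound 1 to compound 4 (0.48 log units; beyond the scatter), so with the rest of the molecule unchanged, this place moves the number in both directions from the level of compound 1, and a group with no aromatic ring and no hetero atom reaches the higher side. No measurement at hand gives a reason for either step.

Among the compounds shown here, with only three groups compared here, ring size, aromatic character, hetero atoms and group size all change together and cannot be separated. From the compounds shown here alone, it remains open where a plain phenyl, an open-chain propyl or an amine on this carbon would fall relative to cyclopropyl and pyridin-3-yl.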